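From 3,4,5-trihydroxyphenyl to 4-hydroxy-3-methoxyphenyl: working notes

This account rests on a few compounds, and the source may have more. Where it says the series, first, only, none or still open, it means among the compounds named here.

Of the compounds shown here, two have numbers so far in a physicochemical assay, read by spectrophotometry, with a stated time of 6 min (on this read-out higher numbers stand for weaker inhibition and lower numbers for stronger inhibition), as the read-out. Compound 1 (`O=C(CCc1nc2ccccc2c(=O)[nH]1)N/N=C/c1ccc([N+](=O)[O-])cc1`) gives 220000000 nM as its half-maximal inhibitory concentration. Compound 2 (`O=C(CCCc1nc2ccccc2c(=O)[nH]1)N/N=C/c1cc(O)c(O)c(O)c1`) gives 40000000 nM and so holds the lower of the two numbers, with compound 1 higher by a gap beyond the usual scatter. These two compounds differ in more than one place, so the gap cannot be assigned to any single group.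

Compound 3 (`COc1cc(/C=N/NC(=O)CCCc2nc3ccccc3c(=O)[nH]2)ccc1O`) has not yet been measured. It keeps the rest of compound 2 and carries 4-hydroxy-3-methoxyphenyl in place of 3,4,5-trihydroxyphenyl on a carbon with a double bond to nitrogen. Within the data shown here, no measured pair isolates a change at this place, so the expectation is loose and rests only on the span of the two known values. The expected move in this assay is toward a higher number, meaning weaker inhibition, and a 2.5-fold higher number from compound 2 to compound 3 (0.40 log units; beyond the scatter) is the estimated size of that move, modestly beyond the scatter. Compound 3 is estimated at 100000000 nM with 40000000 nM to 280000000 nM as the expected range.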

Compound 3, half-maximal inhibitory concentration: 115000000 nM
Compound 3: middle estimate off by 1.2-fold (0.06 log units), on the low side; measured number inside the range.
By their numbers in this assay, from the lowest: compound 2; then compounds 3 and 1 (each within the scatter of the next).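

In this assay, among these compounds, this is the first comparison that isolates one place: 4-hydroxy-3-methoxyphenyl in place of 3,4,5-trihydroxyphenyl on a carbon with a double bond to nitrogen gives a 2.9-fold higher number from compound 2 to compound 3 (0.46 log units; beyond the scatter) as a modest move toward weaker inhibition. The aryl group at this place therefore affects the read-out, and of the two groups compared on this chain, 3,4,5-trihydroxyphenyl gives the stronger inhibition, even though the entering group has the same heavy-atom count, with 1 hydrogen-bond donor and 2 acceptors against 3 of each. No measurement available here ties the step to any particular feature of either group.

The change swaps several features at once, so the compounds shown do not separate the contribution of the methoxy group from that of the hydroxy groups, and a 3,4-dihydroxyphenyl group or an amine on the same ring would be needed to pull these apart. Compound 1 differs from compound 2 and compound 3 in more than one place, so the effect of its nitro group and of a longer or shorter chain remains unresolved.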